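The compounds below may be only part of what the source reports. "The series", "measured", "known", "first", "only" and "open" are said of these compounds alone.

Measured so far in a functional assay on the whole organism (Sciatic nerve) for inhibition, with Rattus norvegicus as the target, at a dose of 25 mg/kg; a higher number here means more inhibition at the dose given (going by the name of the read-out), a lower number less inhibition:

Compound 1, `O=C(O)Cc1nn(Cc2nc3cc(F)cc(F)c3s2)c(=O)c2cccnc12`: 68%

Compound 2, `O=C(O)Cc1nn(Cc2nc3cc(C(F)(F)F)ccc3s2)c(=O)c2cccnc12`: 74%

Compound 3, `O=C(O)Cc1nn(Cc2nc3cc(C(F)(F)F)ccc3s2)c2ccccc12`: 59%

Compound 2 gives the highest of these three numbers. Its gap to compound 1 lies within the usual scatter of repeated measurements, so the two cannot be told apart; its gap to compound 3 lies beyond that scatter. Compound 4, `O=C(O)Cc1nn(Cc2nc3cc(F)ccc3s2)c(=O)c2cccnc12`, has not yet been measured. It differs from compound 2 in one place: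

fluoro in place of trifluoromethyl on an aromatic carbon

Within the data shown here, no measured pair differing in one place exists to show the size of such a change. Compound 1, whose substituents are fluoro rather than trifluoromethyl, gives 68%, close to compound 2. The step of a number 6 percentage points lower from compound 2 to compound 4 (within the scatter) is therefore expected to be small, not beyond the scatter. Compound 4 is estimated at 68%, between 55% and 80%.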

Compound 4, a percentage reported as inhibition, in the whole organism at one dose (the size of the read-out at that dose, not a potency): 64%
Compound 4: middle estimate off by 4 percentage points, on the high side; low and high end bracket the measured number.
By their numbers in this assay, from the lowest: compounds 3, 4, 1 and 2 (each within the scatter of the next, the first and the last beyond it).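

In this assay, among these compounds, fluoro in place of trifluoromethyl on this aromatic carbon gives a number 10 percentage points lower from compound 2 to compound 4 (within the scatter), the first direct reading of this change: the much smaller group leaves no difference that can be told from the scatter. Hydrogen in place of fluoro on an aromatic carbon gives a number 4 percentage points lower from compound 1 to compound 4 (within the scatter), so that change cannot be told from the scatter either. Nothing measured here gives a reason for either step. As far as these compounds go, whether an amine or a nitrile on this aromatic carbon would keep the number stays open. Also open, from the compounds shown here alone, is whether fluoro in place of trifluoromethyl would behave alike on the core of compound 3.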